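Acid to sulfonyl-ethyl amide on the shared core

A few compounds are considered here, and "the series" means these few. Any claim that something is new, unique, unknown or untested is made for them only; others in the source may bear on it.

Compound 1 `O=c1n(Cc2cn3ccc(Cl)cc3n2)c2cnccc2n1C1CC1` gives 22300 nM in an ADME assay on HEp-2 cells (Homo sapiens) for cytotoxicity, read by CCK-8 assay, with a stated time of 6 days; a higher number here means that more compound is tolerated, a lower number that less compound is tolerated. On these data alone, compound 2 `O=C(O)c1c(Cn2c(=O)n(C3CC3)c3ccncc32)nc2cc(Cl)ccn12` reaches only the limit > 100000 nM in this assay, so its true number is unknown. The step of an at least 4.4-fold higher number from compound 1 to compound 2 (0.65 log units; beyond the scatter) stands on that limit (the limit of > 100000 nM in this assay, at which 1 of the 2 values shown sits). Compound 3 `CS(=O)(=O)CCNC(=O)c1c(Cn2c(=O)n(C3CC3)c3ccncc32)nc2cc(Cl)ccn12` differs from compound 2 by (2-(methylsulfonyl)ethyl)amino in place of hydroxy on a carbonyl carbon. Within the data shown here, no measured step covers this kind of amide change, so no direction beyond the scatter is indicated. Compound 3 is therefore expected to give about 80000 nM (range 20000 nM to 200000 nM). That estimate means a step of an at least 1.2-fold lower number from compound 2 to compound 3 (0.09 log units; that floor lies within the scatter), which is only an expectation.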

Compound 3, half-maximal cytotoxic concentration: > 100000 nM
Compound 3: only a limit was reported; the forecaster's own chance of this, stated with the estimate: 55%; middle value at least 1.2-fold (0.09 log units) away from the limit.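

In this assay, (2-(methylsulfonyl)ethyl)carbamoyl in place of hydrogen on the aromatic carbon gives an at least 4.4-fold higher number from compound 1 to compound 3 (0.65 log units; beyond the scatter). The rise over compound 1 therefore does not depend on a free carboxy group, since an amide at this place gives it too. Compound 2 and compound 3 cannot be ranked against each other, because neither gives a true number: the limit of > 100000 nM in this assay, at which 2 of the 3 values shown sit.

On these data alone, how much compound either one truly tolerates stays open. So does whether an amine or a longer chain on the carbonyl carbon would also reach that limit.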